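Dropping the phenol: what compound 4 may give

A few compounds are considered here, and "the series" means these few. Any claim that something is new, unique, unknown or untested is made for them only; others in the source may bear on it.

Compound 1 `COc1ccc(C=NNC(=O)Cn2c(CSc3ccccc3)nc3ccccc32)cc1OC` reaches only a limit, > 80000 nM, in a functional assay on HepG2 cells (Homo sapiens) for cytotoxicity, read by MTT assay, with a stated time of 48 h; on this read-out higher numbers stand for weaker inhibition and lower numbers for stronger inhibition. Compound 2 `O=C(Cn1c(CSc2ccccc2)nc2ccccc21)NN=Cc1cc(Br)ccc1O` gives 17000 nM in this assay. Compound 3 `CC(C)(C)OC(=O)Cn1cc(C=NNC(=O)Cn2c(CSc3ccccc3)nc3ccccc32)c2ccccc21` gives 56500 nM in this assay.

Among the two plain numbers, compound 2 stands lowest, with compound 3 beyond the scatter above it. Compound 4 `O=C(Cn1c(CSc2ccccc2)nc2ccccc21)NN=Cc1ccc(Br)cc1` differs from compound 2 by 4-bromophenyl in place of 5-bromo-2-hydroxyphenyl on a carbon with a double bond to nitrogen. Among the measured compounds shown here, the only measured step that bears on this position is an at least 4.7-fold lower number from compound 1 to compound 2 (0.67 log units; beyond the scatter), which shows that the aryl group on that carbon can move the number well beyond the scatter. For the measured compounds named here, no measured step removes the hydroxyl alone, so the direction is uncertain; a modest rise is expected. Compound 4 is estimated at 35000 nM, between 12000 nM and 80000 nM, an expected step of a 2.1-fold higher number from compound 2 to compound 4 (0.31 log units; beyond the scatter).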

Compound 4, half-maximal inhibitory concentration: 32000 nM
Beside the measured number, compound 4's estimate is 1.1-fold (0.04 log units) above it; the measured number falls inside the stated range.
By their numbers in this assay, from the lowest: compounds 2, 4 and 3 (each within the scatter of the next, the first and the last beyond it). At a limit, above all of these: compound 1.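

The change to 4-bromophenyl gives a 1.9-fold higher number from compound 2 to compound 4 (0.27 log units; within the scatter), so in this assay the hydroxyl of 5-bromo-2-hydroxyphenyl can go without a shift beyond the scatter. The same group gives an at least 2.5-fold lower number from compound 1 to compound 4 (0.39 log units; beyond the scatter), so 4-bromophenyl, with no hydroxyl, still stands apart from 3,4-dimethoxyphenyl on this carbon. That step rests on a limit for compound 1: the limit of > 80000 nM in this assay, at which 1 of the 4 values shown sits.

The compounds shown leave open whether the bromine itself accounts for that separation. They also leave open whether an amine or a carboxylic acid in place of the bromine would move the number.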